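Swapping hydroxy for carboxy on two related amide cores

A few compounds are considered here, and "the series" means these few. Any claim that something is new, unique, unknown or untested is made for them only; others in the source may bear on it.

Of the compounds shown here, three have been measured in a functional assay on A-375 cells (Homo sapiens) for antiproliferative activity, read by MTT assay, with a stated time of 24 h, tested at 0.01 ug/mL; a lower number here means a weaker effect, a higher number a stronger effect of the compound at the concentration tested. Compound 1, `CCc1ccc2nc(C(=O)Nc3c(F)cc(-c4cccc(F)c4)cc3F)c(C)c(O)c2c1`, gives -0.35% in this assay. Compound 2, `COc1ccc2nc(C(=O)Nc3ccc(-c4ccccc4)cc3)c(C)c(O)c2c1`, gives 0.13% in this assay. Compound 3, `CCc1ccc2nc(C(=O)Nc3c(F)cc(-c4cccc(F)c4)cc3F)c(C)c(C(=O)O)c2c1`, gives -0.45% in this assay. All three numbers sit close to zero and within the usual scatter of one another, so no order among them can be read from these data.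

Compound 3 is compound 1 with one change: carboxy in place of hydroxy on an aromatic carbon. That change made a step of a number 0.1 percentage points lower from compound 1 to compound 3 (within the scatter), which is within the scatter. Compound 2 has a different core from compound 1; the difference between the two cores is not broken down here.

Compound 4, `COc1ccc2nc(C(=O)Nc3ccc(-c4ccccc4)cc3)c(C)c(C(=O)O)c2c1`, has not yet been measured. It stands to compound 2 exactly as compound 3 stands to compound 1: carboxy in place of hydroxy on an aromatic carbon. The place of the change is described in the same words in both cases, so it is the same change made on a second core.

In this assay the step from compound 2 to compound 4 is expected to be a number 0.1 percentage points lower from compound 2 to compound 4 (within the scatter), beside the earlier step; this expectation rests on compound 1 and compound 3, because a number 0.1 percentage points lower from compound 1 to compound 3 (within the scatter) lay within the scatter. For compound 4 the estimated value in this assay is 0%, likely falling between -8% and 8%.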

Compound 4, a percentage reported as inhibition, at one concentration (the size of the read-out at that concentration, not a potency): 0.35%
Compound 4: middle estimate off by 0.4 percentage points, on the low side; the measured number falls inside the stated range.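

In this assay the swap of hydroxy for carboxy on the second core gave a step of a number 0.2 percentage points higher from compound 2 to compound 4 (within the scatter), so on this core, as on the first, the change produced nothing that can be told apart from ordinary repeat-to-repeat variation. Set side by side, the two steps do not differ, and in that narrow sense the change carried over from one core to the other: the same change on two cores in this assay, a number 0.1 percentage points lower (within the scatter) from compound 1 to compound 3 and a number 0.2 percentage points higher (within the scatter) from compound 2 to compound 4, 0.3 percentage points apart, within the scatter of two such steps. This agreement is weak evidence, however: all four compounds read close to zero at the single concentration tested, so two flat results match without showing that the change would have the same effect on both cores in a setting where these compounds clearly act on the cells.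

The compounds shown carry only hydroxy or carboxy at this place, which leaves open whether an amine, a methyl ester or a longer chain there would lift the read-out clear of zero. Going by these compounds, the two cores also differ in more than one place, including ethyl against methoxy and the presence of fluorine on the biphenyl part, so what each of those differences contributes on its own also remains open.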